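A few compounds are considered here, and "the series" means these few. Any claim that something is new, unique, unknown or untested is made for them only; others in the source may bear on it.

Measured so far, in a functional assay on NCI-H1975 cells (Homo sapiens) for antiproliferative activity, read by MTT assay, with a stated time of 72 h; on this read-out higher numbers stand for weaker inhibition and lower numbers for stronger inhibition:

Compound 1 `COc1cc(F)c(NC(=O)c2ccncc2OC)cc1Nc1nccc(-c2cn(C)c3ccccc23)n1`: compound 1 gives 4120 nM.
Compound 2 `COc1ccc(C(=O)Nc2cc(Nc3nccc(-c4cn(C)c5ccccc45)n3)c(OC)cc2F)nc1`: compound 2 gives 16800 nM.
Compound 3 `COc1cc(N(C)C)c(NC(=O)c2ccncc2OC)cc1Nc1nccc(-c2cn(C)c3ccccc23)n1`: compound 3 gives 12100 nM.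

Compound 2 differs from compound 1 by 5-methoxypyridin-2-yl in place of 3-methoxypyridin-4-yl on a carbonyl carbon, and this change gave a 4.1-fold higher number from compound 1 to compound 2 (0.61 log units; beyond the scatter). Compound 3 differs from compound 1 by dimethylamino in place of fluoro on an aromatic carbon, giving a 2.9-fold higher number from compound 1 to compound 3 (0.47 log units; beyond the scatter). Compound 4 `COc1ccc(C(=O)Nc2cc(Nc3nccc(-c4cn(C)c5ccccc45)n3)c(OC)cc2N(C)C)nc1` has not yet been tested in this assay; it differs from compound 3 by 5-methoxypyridin-2-yl in place of 3-methoxypyridin-4-yl on a carbonyl carbon, the same kind of change as between compound 1 and compound 2, here made on the core of compound 3 rather than that of compound 1. Since the earlier change weakened inhibition, a similar step is expected here, so that the estimated result for compound 4 is a 3.7-fold higher number from compound 3 to compound 4 (0.57 log units; beyond the scatter). Compound 4 is therefore expected to give about 45000 nM, with a plausible range from 20000 nM to 100000 nM.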

Compound 4, half-maximal inhibitory concentration: 2130 nM
Beside the measured number, compound 4's estimate is 21-fold (1.32 log units) above it, outside the stated range (below it).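

In this assay the change to 5-methoxypyridin-2-yl on the carbonyl carbon now gives a 5.7-fold lower number from compound 3 to compound 4 (0.75 log units; beyond the scatter) and so runs opposite to its effect on the core of compound 1, which shows that this change did not carry from one core to the other: the same change on two cores in this assay, a 4.1-fold higher number (0.61 log units; beyond the scatter) from compound 1 to compound 2 and a 5.7-fold lower number (0.75 log units; beyond the scatter) from compound 3 to compound 4, 23-fold (1.36 log units) apart, beyond the scatter of two such steps.
Seen from the other side, dimethylamino in place of fluoro gives a 7.9-fold lower number from compound 2 to compound 4 (0.90 log units; beyond the scatter) and also reverses its earlier direction: the same change on two cores in this assay, a 2.9-fold higher number (0.47 log units; beyond the scatter) from compound 1 to compound 3 and a 7.9-fold lower number (0.90 log units; beyond the scatter) from compound 2 to compound 4, 23-fold (1.36 log units) apart, beyond the scatter of two such steps.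
The two changes therefore do not act independently in these four compounds, but the numbers do not show why, nor how either change would behave on any further core.

From the compounds shown here alone, it remains open whether piperazine in place of dimethylamino would keep the stronger inhibition seen with compound 4. A morpholine there is equally untested by the compounds shown.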